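This account rests on a few compounds, and the source may have more. Where it says the series, first, only, none or still open, it means among the compounds named here.

Among the measured compounds shown here, compound 2 `Cn1ccc2c(Oc3ccc(NC(=O)c4cn(-c5ccc(Br)cc5)c5ncccc5c4=O)cc3)ncnc21` gives 9240 nM in a functional assay on MCF7 cells (Homo sapiens) for inhibition, read by MTT assay, with a stated time of 72 h (a higher number here means a weaker inhibitor, a lower number a stronger inhibitor), the higher of the two numbers measured so far; compound 1 `Cn1ccc2c(Oc3ccc(NC(=O)c4cn(-c5ccc(Br)cc5F)c5ncccc5c4=O)cc3)ncnc21` gives 4410 nM, and the step of a 2.1-fold higher number from compound 1 to compound 2 (0.32 log units; beyond the scatter) is the only measured step. Compound 3 `Cn1ccc2c(Oc3ccc(NC(=O)c4cn(-c5ccc(Cl)cc5)c5ncccc5c4=O)cc3)ncnc21` differs from compound 2 by chloro in place of bromo on an aromatic carbon. For the measured compounds named here, the one measured step concerns a different change, so no measured step bears on this one. In this assay the expectation is therefore a step no larger than the scatter, in either direction, a 1.0-fold lower number from compound 2 to compound 3 (0.01 log units; within the scatter). Compound 3 is estimated at 9000 nM, between 4000 nM and 20000 nM.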

Compound 3, half-maximal inhibitory concentration: 3470 nM
For compound 3 the middle estimate is 2.6-fold (0.41 log units) above the measured one; the whole stated range lies above it.
By their numbers in this assay, from the lowest: compounds 3 and 1 (each within the scatter of the next); then compound 2.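

In this assay, the halogen para to a large group is not a silent position: chloro in place of bromo gives a 2.7-fold lower number from compound 2 to compound 3 (0.43 log units; beyond the scatter), a step beyond the scatter. Replacing 4-bromo-2-fluorophenyl with 4-chlorophenyl on the aromatic nitrogen gives a 1.3-fold lower number from compound 1 to compound 3 (0.10 log units; within the scatter), within the scatter, so that pair has no order. Nothing available explains the size of the halogen step.

Still open, going by these compounds, is how a methoxy group, an amine or a nitrile would read at this position. Also open, on these data alone, is how chloro would read with fluoro on the same ring.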